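Phenylethylamine replaces hydroxyindanylamine on the piperidine series

A few compounds are considered here, and "the series" means these few. Any claim that something is new, unique, unknown or untested is made for them only; others in the source may bear on it.

Measured compounds:
Compound 1 `c1ccc(CNCC2CCN(CCCc3c[nH]c4ccc(-n5cnnc5)cc34)CC2)cc1` with 28 nM
Compound 2 `O[C@@H]1Cc2ccccc2[C@H]1NC1CCN(CCCc2c[nH]c3ccc(-n4cnnc4)cc23)CC1` with 210 nM

Compound 2 gives the higher of the two numbers in an assay on CHO cells for displacement of a labelled ligand from 5-hydroxytryptamine receptor 1B (Homo sapiens); a lower number here means a stronger inhibitor, a higher number a weaker inhibitor; its nearest neighbour is compound 1, and the step of a 7.5-fold higher number from compound 1 to compound 2 (0.88 log units; beyond the scatter) is beyond the scatter, so compound 2 is the weaker of the two in this assay.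

Compound 3 `C[C@H](NCC1CCN(CCCc2c[nH]c3ccc(-n4cnnc4)cc23)CC1)c1ccccc1` differs from compound 2 in one place: ((1-phenylethyl)amino)methyl in place of (2-hydroxy-2,3-dihydro-1H-inden-1-yl)amino on a saturated ring carbon. The group that enters resembles the group carried by compound 1, differing from it only by the additional methyl on the carbon next to the nitrogen of the amine. Among the compounds with values here, the only step that bears on this change is a 7.5-fold higher number from compound 1 to compound 2 (0.88 log units; beyond the scatter), which went from the benzylamine-type group to the hydroxyindane and raised the number by a modest amount. Undoing that change in compound 3 should therefore bring the number back toward that of compound 1, and the step of a 6.0-fold lower number from compound 2 to compound 3 (0.78 log units; beyond the scatter) is expected to be a lowering beyond the scatter. Compound 3 is estimated at 35 nM, with a range from 12 nM to 110 nM.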

Compound 3, half-maximal inhibitory concentration: 58 nM
Beside the measured number, compound 3's estimate is 1.7-fold (0.22 log units) below it, and the stated range covers the measured number.
By their numbers in this assay, from the lowest: compound 1; then compound 3; then compound 2.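

In this assay, the step of a 3.6-fold lower number from compound 2 to compound 3 (0.56 log units; beyond the scatter) shows that this saturated ring carbon, three ring bonds from the ring nitrogen, tolerates an open-chain ((1-phenylethyl)amino)methyl group better than the (2-hydroxy-2,3-dihydro-1H-inden-1-yl)amino group. The step of a 2.1-fold higher number from compound 1 to compound 3 (0.32 log units; beyond the scatter) adds what the earlier pair could not show: a methyl on the saturated chain carbon bound to the amine nitrogen and the aromatic carbon is enough on its own to move the number beyond the scatter, so the recovery from the hydroxyindanyl compound stops short of the unbranched benzylamine. No supporting evidence accompanies these results to explain either step.

The exchange from compound 2 to compound 3 alters several features at once, so the compounds shown do not separate the contribution of the hydroxyl from that of the closed five-membered ring or of the methylene that carries the amine, which a 2,3-dihydro-1H-inden-1-ylamino group lacking the hydroxyl, or a (1-phenylethyl)amino group set directly on the ring carbon, would address. Going by these compounds, only one configuration of the 1-phenylethyl stereocentre appears here, so the opposite enantiomer and larger branches such as an ethyl in place of the methyl remain open.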